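A few compounds are considered here, and "the series" means these few. Any claim that something is new, unique, unknown or untested is made for them only; others in the source may bear on it.

Measured so far, in a physicochemical assay for solubility, at pH 7.4; a higher number here means a more soluble compound, a lower number a less soluble compound:
compound 1 `Cc1ccc(-c2nccn2C)cc1NC(=O)c1ccc(OCc2ccccn2)cc1`: 192000 nM
compound 2 `Cc1ccc(-c2ncc[nH]2)c(C)c1NC(=O)c1ccc(OCc2ccccn2)cc1`: 69000 nM
compound 3 `Cc1cc(C)c(-c2nc3ccccc3[nH]2)cc1NC(=O)c1ccc(OCc2ccccn2)cc1`: < 1000 nM

Compound 3 stands at the limit of < 1000 nM in this assay, at which 1 of the 3 values shown sits, which is a limit of the assay and not a measured number. Compound 1 and compound 2, by contrast, give real numbers far from that limit. Compound 4 `Cc1cc(C)c(-c2ccc(N)nn2)cc1NC(=O)c1ccc(OCc2ccccn2)cc1` differs from compound 3 in one place: 6-aminopyridazin-3-yl in place of 1H-benzimidazol-2-yl on an aromatic carbon. For the measured compounds named here, no pair of measured compounds shows this kind of change, and compound 3 itself provides only a limit, so the expectation rests on the structural change alone. The expected step, an at least 30-fold higher number from compound 3 to compound 4 (1.47 log units; beyond the scatter), points upward and beyond the usual scatter. Compound 4 is estimated at 30000 nM, within a range from 5000 nM to 150000 nM.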

Compound 4, solubility: 6000 nM
Beside the measured number, compound 4's estimate is 5.0-fold (0.70 log units) above it, and the stated range covers the measured number.
By their numbers in this assay, from the lowest: compound 4; then compound 2; then compound 1. At a limit, below all of these: compound 3.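

On this aromatic carbon, 6-aminopyridazin-3-yl in place of 1H-benzimidazol-2-yl gives, in this assay, an at least 6.0-fold higher number from compound 3 to compound 4 (0.77 log units; beyond the scatter). Compound 3 gives only a limit and not a measured number: the limit of < 1000 nM in this assay, at which 1 of the 4 values shown sits.

Compound 4, unlike compound 3, gives a real number, so this change at this position lifts the read-out clear of that limit. The compounds shown leave open whether the amine or the ring of 6-aminopyridazin-3-yl accounts for the step. A pyridazin-3-yl group without the amine, or a carboxylic acid on this carbon, would help separate the two.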